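The compounds below may be only part of what the source reports. "The series", "measured", "known", "first", "only" and "open" are said of these compounds alone.

Measured so far in a functional assay on HEL cells (Homo sapiens) for inhibition; a lower number here means that less compound is tolerated, a higher number that more compound is tolerated:

- compound 1, `O=C1c2ccccc2N(Cc2ccc(Cl)c(Cl)c2)S(=O)(=O)N1Cc1ccccc1`: the value > 200000 nM is a limit of this assay, not a number.
- compound 2, `O=S1(=O)N=C(OCc2ccccc2)c2ccccc2N1Cc1ccccc1`: the value > 200000 nM is likewise a limit of this assay.

Within the data shown here, compound 1 therefore stands at the edge of what this assay reports: it has no numerical half-maximal cytotoxic concentration, only a limit, and the one further value shown, for compound 2, is a limit too. Both values sit at the same place, as stated in the limit of > 200000 nM in this assay, at which 2 of the 2 values shown sit. Among the measured compounds shown here, no step between measured compounds exists here, so no measured step size can be taken as a guide.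

The unmeasured compound is compound 3, `O=C1c2ccccc2N(Cc2ccc(Cl)cc2)S(=O)(=O)N1Cc1ccccc1`. It differs from compound 1 by hydrogen in place of chloro on an aromatic carbon, so that the 3,4-dichlorobenzyl of compound 1 becomes a 4-chlorobenzyl. The change is a single heavy atom with no ring, no donor, no acceptor and no charge.

With both values shown sitting at the limit, the expectation for compound 3 in this assay is a step of a number no higher from compound 1 to compound 3 (the limit leaves the size open), that is, none beyond the scatter. Compound 3 is estimated at 200000 nM, with a range from 100000 nM to 400000 nM, most probably again reported only as a limit.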

Compound 3, half-maximal cytotoxic concentration: > 200000 nM
Compound 3: no number, only a limit (the forecaster's own chance of this, stated with the estimate: 85%); the middle value sits exactly at the limit.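

In this assay compound 3 gives > 200000 nM, a limit of the assay and not a number. Compound 1 also carries only a limit, so no step can be read between compound 1 and compound 3. The compounds shown leave open whether hydrogen in place of chloro changes the half-maximal cytotoxic concentration at all, and where any numerical value for this series would lie.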